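The compounds below may be only part of what the source reports. "The series", "measured", "known", "first", "only" and "open" are said of these compounds alone.

In a functional assay on THP-1 cells (Homo sapiens) (a higher number here means a weaker inhibitor, a lower number a stronger inhibitor), compound 1 (`CCSC[C@@](O)([C@@H](Nc1cccc2nc(C)ccc12)c1ccc(C)cc1)C(F)(F)F`) gives 2.51 nM, while compound 2 (`COc1ccc([C@H](Nc2cccc3nc(C)ccc23)[C@](O)(CSC)C(F)(F)F)c(Cl)c1F`) gives 0.126 nM, the lower of the two numbers, with a gap beyond the scatter. Compound 3 (`COc1ccc([C@H](Nc2cccc3nc(C)ccc23)[C@](O)(CC#N)C(F)(F)F)c(Cl)c1F`) differs from compound 2 at one place: cyano in place of methylsulfanyl on a saturated chain carbon, two bonds along the chain from an oxygen on a saturated carbon. For the measured compounds named here, no measured pair shows this change, so the expectation in this assay is loose: a modest rise in the number, meaning a somewhat weaker inhibitor. The expected step is a 3.2-fold higher number from compound 2 to compound 3 (0.50 log units; beyond the scatter). For compound 3 the estimated value is 0.4 nM, with an expected range of 0.08 nM to 2 nM.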

Compound 3, half-maximal inhibitory concentration in the THP-1 assay: 1.26 nM
For compound 3 the middle estimate is 3.2-fold (0.50 log units) below the measured one, within the range that was stated.
By their numbers in the THP-1 assay, from the lowest: compound 2; then compounds 3 and 1 (each within the scatter of the next).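

In the THP-1 assay, the first measured case of cyano in place of methylsulfanyl on this saturated chain carbon gives a 10-fold higher number from compound 2 to compound 3 (1.00 log units; beyond the scatter), so this position responds clearly to the exchange, even though both groups have the same heavy-atom and hydrogen-bond acceptor counts. In a physicochemical assay for lipophilicity (a higher number here means a more lipophilic compound, a lower number a more polar compound), compound 2 gives 4.5 and compound 3 gives 3.4. Compound 3 is also the more polar compound in the physicochemical assay: the measured partition coefficient of compound 2, 4.5, and of compound 3, 3.4, a number 1.10 log units lower (beyond the scatter). On these data alone, with a single pair, it remains open whether the weaker inhibition in the THP-1 assay is tied to the lower partition coefficient, and how an amine or a longer thioether chain would read at this place.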